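The compounds below may be only part of what the source reports. "The series", "measured", "known", "first", "only" and "open" are said of these compounds alone.

Compound 1 `CCCN(CC[C@H]1CC[C@H](NC(=O)/C=C/c2ccc(F)cc2)CC1)[C@H]1CCc2nc(N)sc2C1` gives 1 nM in an assay on brain for displacement of a labelled ligand from D(3) dopamine receptor (Rattus norvegicus) (on this read-out higher numbers stand for weaker inhibition and lower numbers for stronger inhibition), the lowest of the three numbers recorded. Compound 3 `CCCN(CC[C@H]1CC[C@H](NC(=O)/C=C/c2ccccc2Cl)CC1)[C@H]1CCc2nc(N)sc2C1` gives 1.2 nM in this assay, and the step of a 1.2-fold higher number from compound 1 to compound 3 (0.08 log units; within the scatter) lies within the scatter. Compound 2 `CCCN(CC[C@H]1CC[C@H](NC(=O)/C=C/c2cccc(F)c2)CC1)[C@H]1CCc2nc(N)sc2C1` gives 9.9 nM in this assay, so the step of a 9.9-fold higher number from compound 1 to compound 2 (1.00 log units; beyond the scatter) is beyond the scatter, as is the step of an 8.3-fold lower number from compound 2 to compound 3 (0.92 log units; beyond the scatter). Compound 4 `CCCN(CC[C@H]1CC[C@H](NC(=O)c2ccc(-n3ccnc3)cc2)CC1)[C@H]1CCc2nc(N)sc2C1` differs from compound 1 in one place: 4-(1H-imidazol-1-yl)phenyl in place of 2-(4-fluorophenyl)ethenyl on a carbonyl carbon. The measured steps all vary the ring attached to the ethenyl chain and keep that chain; none of them removes the 2-(4-fluorophenyl)ethenyl group or brings in a 4-(1H-imidazol-1-yl)phenyl group on the carbonyl carbon, so they bear on this change only loosely. They show that a change of the aromatic part can either leave the number unchanged or shift it by a modest amount. Because compound 1 gives 1 nM and the largest shown step is a 9.9-fold higher number from compound 1 to compound 2 (1.00 log units; beyond the scatter), a step of no more than that size, toward a higher number, is expected in this assay. An estimated step of a 5.0-fold higher number from compound 1 to compound 4 (0.70 log units; beyond the scatter) follows. Compound 4 is estimated at 5 nM, in an expected range from 1 nM to 30 nM.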

Compound 4, inhibition constant: 1.9 nM
Estimate against measurement, compound 4: 2.6-fold (0.42 log units) above, and the stated range covers the measured number.
By their numbers in this assay, from the lowest: compounds 1, 3 and 4 (each within the scatter of the next); then compound 2.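

On the carbonyl carbon, the whole 2-(4-fluorophenyl)ethenyl group can give way to 4-(1H-imidazol-1-yl)phenyl, losing the double bond outside aromatic rings and gaining a five-membered aromatic ring with 2 hetero atoms, with a 1.9-fold higher number from compound 1 to compound 4 (0.28 log units; within the scatter) in this assay and a 1.6-fold higher number from compound 3 to compound 4 (0.20 log units; within the scatter) in the same assay, so among these compounds the ethenyl chain is not needed for a low number. The one clear difference is a 5.2-fold lower number from compound 2 to compound 4 (0.72 log units; beyond the scatter) in this assay, which leaves compound 2 apart from the other three compounds. No measurement shown here accounts for these results.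

The compounds shown leave open whether the imidazole ring itself contributes to the number, since a plain phenyl or a 4-(pyridin-3-yl)phenyl group on the carbonyl carbon does not appear among them. Also open, from the compounds shown here alone, is how a morpholine or a carboxylic acid in place of that imidazole ring would read.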